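The compounds below may be only part of what the source reports. "The series", "measured", "known", "first", "only" and "open" are said of these compounds alone.

Measured so far:
Compound 1 `CC(O)(CS(=O)(=O)c1ccc(Br)cc1)c1nc(-c2ccccc2)no1` gives > 100000 nM in a functional assay on DU-145 cells (Homo sapiens) for cytotoxicity, read by MTT assay (a lower number here means a stronger inhibitor, a higher number a weaker inhibitor), which is a limit of the assay and not a number.
Compound 2 `CC(O)(CSc1ccccc1)c1nc(-c2ccccc2)no1` gives > 100000 nM, again a limit.
Compound 3 `CC(O)(CS(=O)(=O)c1ccccc1)c1nc(-c2ccccc2)no1` gives > 100000 nM, also a limit.

All three values therefore sit at the same limit (the limit of > 100000 nM in this assay, at which 3 of the 3 values shown sit). Compound 1 and compound 3 differ in one place, (bromo in place of hydrogen on an aromatic carbon), and the step that the two limits leave unreadable from compound 3 to compound 1 cannot be read, because both ends of it are limits (the limit of > 100000 nM in this assay, at which 3 of the 3 values shown sit). Compound 4 `CC(O)(CSc1ccc(Br)cc1)c1nc(-c2ccccc2)no1` is not yet measured; it stands to compound 2 as compound 1 stands to compound 3, through the change (bromo in place of hydrogen on an aromatic carbon), the same change made at the same kind of place. How the core of compound 2 differs from the core of compound 3 is not broken down here. Among the measured compounds shown here, for compound 4 only a weak expectation can be formed: because compound 2 sits at the limit of > 100000 nM in this assay, at which 3 of the 3 values shown sit, and because the one earlier step that the two limits leave unreadable from compound 3 to compound 1 is unreadable, the expected step that the limit leaves unreadable from compound 2 to compound 4 rests on nothing firmer than the earlier pair. Compound 4 is therefore expected to lie near 130000 nM, between 40000 nM and 500000 nM, most likely as a limit again.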

Compound 4, half-maximal inhibitory concentration: > 100000 nM
Compound 4: a limit, no number (the forecaster's own chance of this, stated with the estimate: 80%); the middle value is on the limit's open side.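

Among the compounds shown here, compound 2 and compound 4 both end at a limit of the assay rather than at a number, so the change from phenyl to 4-bromophenyl between them gives no step that can be read: the limit of > 100000 nM in this assay, at which 4 of the 4 values shown sit. The compounds shown leave open how strongly any of them acts in this assay, and what the bromo group changes there.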